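Replacing the phosphate-bearing group in a potent sulfonamide

The source may report more compounds than this note shows. Statements on the series, on what has been measured and on what is new or still open speak of the compounds shown alone.

Of the compounds shown here, three have been measured in a functional assay on K562 cells (Homo sapiens) for cytotoxicity, read by trypan blue exclusion, with a stated time of 96 h; a higher number here means a weaker inhibitor, a lower number a stronger inhibitor. Compound 1 `O=S(=O)(/C=C/c1ccccc1)Nc1ccccc1` gives 10000 nM in this assay. Compound 2 `COc1ccc(NS(=O)(=O)/C=C/c2c(F)c(F)c(F)c(F)c2F)cc1N` gives 75000 nM in this assay. Compound 3 `COc1cc(OC)c(/C=C/S(=O)(=O)Nc2ccc(OC)c(OP(=O)(O)O)c2)c(OC)c1` gives 7.5 nM in this assay, the lowest number of the three: compound 1 stands beyond the scatter above it, and compound 2 stands further still, also beyond the scatter. No two of these compounds differ in only one place, so no single step can be read from them.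

Compound 4 `COc1cc(OC)c(/C=C/S(=O)(=O)Nc2ccc(OC)c(NC(C(=O)O)c3ccc(Cl)cc3)c2)c(OC)c1` has not yet been measured in this assay. It differs from compound 3 as follows: a group of 12 heavy atoms (8 carbon, 1 nitrogen, 2 oxygen, 1 chlorine; one six-membered aromatic ring of carbon only) in place of a group of 5 heavy atoms (4 oxygen, 1 phosphorus; no ring), on an aromatic carbon. The group that leaves carries the one phosphorus among the three measured compounds, and nothing measured here tells how the entering (carboxy(4-chlorophenyl)methyl)amino group behaves in this assay.

For the measured compounds named here, with no comparable step to lean on, the account can only expect that so large a change on the aromatic carbon ortho to the methoxy group will move the number, and that the move is more likely upward than downward, beyond the scatter. Compound 4 is therefore estimated at 150 nM in this assay, within a range of 15 nM to 2000 nM, an expected step of a 20-fold higher number from compound 3 to compound 4 (1.30 log units; beyond the scatter).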

Compound 4, half-maximal inhibitory concentration: 15 nM
The estimate for compound 4 lay 10-fold (1.00 log units) above the measured number; low and high end bracket the measured number.
By their numbers in this assay, from the lowest: compounds 3 and 4 (each within the scatter of the next); then compound 1; then compound 2.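

In this assay, putting the (carboxy(4-chlorophenyl)methyl)amino group in place of the phosphorus-bearing group on this aromatic carbon, ortho to a methoxy group and meta to a large group, gives a 2.0-fold higher number from compound 3 to compound 4 (0.30 log units; within the scatter). The earlier compounds shown here could not show this: the single phosphorus among them is not needed for a number at this level on this core, and the position accepts a larger group that brings in a six-membered aromatic ring of carbon only without a step beyond the scatter. Nothing among the data shown explains why the two groups read alike.

Which part of the entering group matters remains open, as the compounds shown do not separate its carboxylic acid, its chlorine and its linking nitrogen from one another. Also unknown is how a simple hydroxyl, or a methyl ester in place of the carboxylic acid, would read at this aromatic carbon, and whether either would stay within the scatter of compound 3.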